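Two chloro additions on a dithiol anilide series

This account rests on a few compounds, and the source may have more. Where it says the series, first, only, none or still open, it means among the compounds named here.

Compound 1 `O=C(CCCCC(S)CCS)Nc1ccccc1` and compound 2 `O=C(CCCCC(S)CCS)Nc1ccc(Cl)cc1` share one core and differ by chloro in place of hydrogen on an aromatic carbon. In a functional assay on KB cells (Homo sapiens) for inhibition, read by MTT assay, with a stated time of 24 h, tested at 10 ug/mL (a higher number here means more inhibition of growth at the concentration tested, a lower number less inhibition of growth), compound 1 gives 8.62%, and compound 2 gives 18.2%; the step is a number 9.6 percentage points higher from compound 1 to compound 2 (within the scatter). Compound 3 `CC(=O)SCCC(CCCCC(=O)Nc1ccccc1)SC(C)=O` rests on a different core; the difference between the two cores is not broken down here. In this assay compound 3 gives 2.5%, the lowest of the three numbers, though only its gap to compound 2 lies beyond the scatter. Compound 4 `CC(=O)SCCC(CCCCC(=O)Nc1ccccc1Cl)SC(C)=O` is not yet measured and differs from compound 3 by chloro in place of hydrogen on an aromatic carbon. This is the same kind of change as that from compound 1 to compound 2, but the place differs: para to a large group there, ortho to a large group here. The earlier step of a number 9.6 percentage points higher from compound 1 to compound 2 (within the scatter) stayed within the scatter. On that basis a similarly small step is expected for compound 4: a number 5.5 percentage points higher from compound 3 to compound 4 (within the scatter). Compound 4 is expected to give 8% in this assay, between 0% and 24%.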

Compound 4, percent growth inhibition at one concentration: 6.55%
The estimate for compound 4 lay 1.5 percentage points above the measured number, within the range that was stated.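

In this assay, chloro in place of hydrogen on the core of compound 3 gives a number 4.1 percentage points higher from compound 3 to compound 4 (within the scatter). Set beside the earlier step, the change looks much the same on both cores: the same change on two cores in this assay, a number 9.6 percentage points higher (within the scatter) from compound 1 to compound 2 and a number 4.1 percentage points higher (within the scatter) from compound 3 to compound 4, 5.5 percentage points apart, within the scatter of two such steps. Among these compounds, this shows only that the step stayed small on both cores, not that the chloro has a real effect that carries from one core to the other: each step lies within the scatter, and the chloro stands ortho to a large group in compound 4 but at a different place in compound 2, so core and place cannot be told apart.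

The compounds shown leave open how chloro would behave at one and the same place on both cores. They also leave open what an amine or a carboxylic acid on the aromatic ring, or a longer chain, would give.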